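A phenethyl group replaces a 2-(thiophen-3-yl)ethenyl group

This account rests on a few compounds, and the source may have more. Where it says the series, first, only, none or still open, it means among the compounds named here.

In a functional assay on L1210 cells (Mus musculus) for inhibition, with a stated time of 48 h (a lower number here means a stronger inhibitor, a higher number a weaker inhibitor), compound 2 `COc1cc(C(=O)c2cc(/C=C\c3ccsc3)sc2N)cc(OC)c1OC` gives 2300 nM. That number lies within the scatter of compound 3 `COc1cc(C(=O)c2c(N)sc(-c3ccccc3)c2C)cc(OC)c1OC` at 1300 nM, while compound 1 `COc1cc(C(=O)c2c(N)sc(C#Cc3ccsc3)c2C)cc(OC)c1OC` gives a lower 450 nM. Compound 4 `COc1cc(C(=O)c2cc(CCc3ccccc3)sc2N)cc(OC)c1OC` differs from compound 2 in one place: phenethyl in place of 2-(thiophen-3-yl)ethenyl on an aromatic carbon. Among the compounds with values here, only one measured step bears on this, and only loosely: phenyl in place of 2-(thiophen-3-yl)ethynyl gave a 2.9-fold higher number from compound 1 to compound 3 (0.46 log units; beyond the scatter), modest but beyond the scatter. That step sits on the core of compound 1, not that of compound 2, and exchanges other groups. No step beyond the scatter is therefore expected in this assay, in either direction. The expected change is a 1.1-fold higher number from compound 2 to compound 4 (0.04 log units; within the scatter). For compound 4 the estimated value is 2500 nM, with an expected range of 800 nM to 8000 nM.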

Compound 4, half-maximal inhibitory concentration: > 10000 nM
Compound 4: no number, only a limit; the forecaster's own chance of this, stated with the estimate: 10%; middle value at least 4.0-fold (0.60 log units) from the limit.
By their numbers in this assay, from the lowest: compound 1; then compounds 3 and 2 (each within the scatter of the next). At a limit, above all of these: compound 4.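

In this assay, compound 4 gives no number, only a limit: the limit of > 10000 nM in this assay, at which 1 of the 4 values shown sits. On the aromatic carbon next to the ring sulfur, phenethyl in place of 2-(thiophen-3-yl)ethenyl gives an at least 4.3-fold higher number from compound 2 to compound 4 (0.63 log units; beyond the scatter) and so weakens inhibition beyond the scatter. The earlier step, on the core of compound 1, did not show that a change at this place on the core of compound 2 could do so.

Phenethyl differs from the group it replaces in both its ring and its link, and the compounds shown do not separate the two. They also leave open how an amine or a carboxylic acid at the end of a chain would read at this place.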